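Adding a Third Methoxy Group to the Side Chain

The source may report more compounds than this note shows. Statements on the series, on what has been measured and on what is new or still open speak of the compounds shown alone.

Compound 1 `Nc1cc(N)c2nc(-c3ccccc3)c(NCc3ccc(Cl)c(Cl)c3)nc2c1` and compound 2 `COc1ccc(CNc2nc3cc(N)cc(N)c3nc2-c2ccccc2)cc1OC` share one core and differ only in the ring on the side chain. In a functional assay on KM12 cells (Homo sapiens) for inhibition, read by sulforhodamine B assay, with a stated time of 48 h (a lower number here means a stronger inhibitor of growth, a higher number a weaker inhibitor of growth), compound 1 gives 3390 nM, while compound 2 gives 13200 nM, the higher of the two numbers; the change a 3.9-fold higher number from compound 1 to compound 2 (0.59 log units; beyond the scatter). Compound 3 `COc1cc(CNc2nc3cc(N)cc(N)c3nc2-c2ccccc2)cc(OC)c1OC` differs from compound 2 by methoxy in place of hydrogen on an aromatic carbon. Going by the values given here, no measured step matches adding a methoxy group; the step from compound 1 to compound 2 touches the same ring but exchanges whole groups. Compound 3 is therefore expected to stay close to compound 2, a 1.1-fold higher number from compound 2 to compound 3 (0.06 log units; within the scatter), giving an estimated 15000 nM with a range of 6000 nM to 40000 nM.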

Compound 3, concentration for 50% growth inhibition: 479 nM
Compound 3: middle estimate off by 31-fold (1.50 log units), on the high side; the measured number lies below the stated range.
By their numbers in this assay, from the lowest: compound 3; then compound 1; then compound 2.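

In this assay, adding one methoxy group to the side-chain ring gives a 28-fold lower number from compound 2 to compound 3 (1.44 log units; beyond the scatter), a much larger change than the exchange of whole groups, a 3.9-fold higher number from compound 1 to compound 2 (0.59 log units; beyond the scatter). This position, ortho to one methoxy group and meta to another, is therefore highly sensitive to a small addition. No available evidence explains the gain in growth inhibition.

As far as these compounds go, it remains open whether the methoxy group itself is needed at this position or whether another group, such as an ethoxy group or an amine, would produce a similar step.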